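The source may hold more compounds than are shown below. What is called first, only, known or untested is meant among the compounds shown, and "the series" means these compounds.

Working notes on the series. Compound 1 `O=C(CCCc1ccc([N+](=O)[O-])cn1)N1CCc2c(Cl)c(O)c(O)c(Cl)c2C1` and compound 2 `O=C(CCCc1ccc(Cl)cn1)N1CCc2c(Cl)c(O)c(O)c(Cl)c2C1` share the same core and differ only in the group on the pyridine ring. In a functional assay (Homo sapiens), tested at 10 uM (on this read-out higher numbers stand for a weaker effect at the one concentration tested and lower numbers for a stronger effect), compound 1 gives 33%, while compound 2 gives 15%, the lower of the two numbers shown, the single measured step being a number 18 percentage points lower from compound 1 to compound 2 (beyond the scatter). Compound 3 `N#Cc1ccc(CCCC(=O)N2CCc3c(Cl)c(O)c(O)c(Cl)c3C2)nc1` is not yet measured; it carries cyano in place of chloro on an aromatic carbon. For the measured compounds named here, only the step from compound 1 to compound 2 touches the same position, and it concerns a different entering group, so it bears on the new change indirectly at best. Going by the values given here, with no direct precedent for cyano in place of chloro, the expectation is for a step of a number 7 percentage points higher from compound 2 to compound 3 (within the scatter), small enough that it may well lie within the scatter. Compound 3 is therefore estimated at 22%, with a range from 10% to 38%.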

Compound 3, a percentage reported as activity, at one concentration (the size of the read-out at that concentration, not a potency): 34%
Beside the measured number, compound 3's estimate is 12 percentage points below it, and the stated range covers the measured number.
By their numbers in this assay, from the lowest: compound 2; then compounds 1 and 3 (each within the scatter of the next).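

In this assay, the change of chloro to cyano gives a number 19 percentage points higher from compound 2 to compound 3 (beyond the scatter) and so does not preserve the lower number of the 5-chloropyridin-2-yl compound at this place, para to a large group. Cyano and nitro are not separated here, with a number 1 percentage points higher from compound 1 to compound 3 (within the scatter), which leaves compound 2 as the only one of the three set apart, while compound 1 and compound 3 sit together at the higher level. No data available here account for the difference between chloro and the other two groups.

On these data alone, it remains open whether a bromine, a methyl group, a methoxy group or an amine at this place would track chloro or sit with cyano and nitro. Equally open, as far as these compounds go, is whether the chloro advantage would persist with a longer chain between the pyridine ring and the amide carbonyl.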